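Sulfonyl group change: compound 2 to compound 3

A few compounds are considered here, and "the series" means these few. Any claim that something is new, unique, unknown or untested is made for them only; others in the source may bear on it.

In a functional assay on DU-145 cells (Homo sapiens) for inhibition, read by trypan blue exclusion, with a stated time of 96 h (a lower number here means a stronger inhibitor of growth, a higher number a weaker inhibitor of growth), compound 1 (`Cc1ccc(C)c(/C=C(\C(=O)c2ccc(Br)cc2)S(=O)(=O)Cc2ccc(F)cc2)c1`) gives 1000 nM and compound 2 (`Cc1ccc(S(=O)(=O)/C(=C/c2ccc(Br)cc2)C(=O)c2ccc(Br)cc2)cc1`) gives 10000 nM as the higher of the two numbers, a gap beyond the usual scatter. Compound 3 (`O=C(/C(=C\c1ccc(Br)cc1)S(=O)(=O)Cc1ccc(F)cc1)c1ccc(Br)cc1`) has 4-fluorobenzyl in place of 4-methylphenyl on a sulfonyl sulfur. Compound 1 also carries 4-fluorobenzyl on a sulfonyl sulfur and stands at 1000 nM here, so a move towards a lower number is expected. An estimated step of a 5.0-fold lower number from compound 2 to compound 3 (0.70 log units; beyond the scatter) is expected, beyond the scatter. For compound 3 the expected value is 2000 nM (estimated range 500 nM to 8000 nM).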

Compound 3, concentration for 50% growth inhibition: 25000 nM
Compound 3: the middle estimate sits 13-fold (1.10 log units) below what was measured; measured number outside the range, above it.
By their numbers in this assay, from the lowest: compound 1; then compound 2; then compound 3.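

In this assay, 4-fluorobenzyl in place of 4-methylphenyl on a sulfonyl sulfur gives no gain when 4-bromophenyl stays on the double-bonded chain carbon (a 2.5-fold higher number from compound 2 to compound 3 (0.40 log units; beyond the scatter)). With 4-fluorobenzyl held constant, 4-bromophenyl in place of 2,5-dimethylphenyl gives the larger change (a 25-fold higher number from compound 1 to compound 3 (1.40 log units; beyond the scatter)), so the lower number of compound 1 cannot be credited to 4-fluorobenzyl alone. No supporting data bear on either step.

Open: whether an amine or a longer chain in place of 4-fluorobenzyl on a sulfonyl sulfur would lower the number, and how 2,5-dimethylphenyl behaves with 4-methylphenyl there.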